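The source may report more compounds than this note shows. Statements on the series, on what has been measured and on what is new or still open speak of the compounds shown alone.

Measured so far:
- Compound 1 `Cc1ccc2c(c1)[n+]([O-])c(N)n[n+]2[O-]` gives 3000000 nM in a physicochemical assay for solubility, in the presence of a further agent that is not named here; on this read-out higher numbers stand for higher solubility and lower numbers for lower solubility.
- Compound 2 `Cc1ccc2c(c1)[n+]([O-])c(NCCN(C)C)n[n+]2[O-]` gives > 51000000 nM in this assay; this is a limit of the assay, not a number.

Compound 2 therefore sits at the limit of > 51000000 nM in this assay, at which 1 of the 2 values shown sits, so only a lower bound is known for it. Among the measured compounds shown here, the one measured step, an at least 17-fold higher number from compound 1 to compound 2 (1.23 log units; beyond the scatter), concerns a different change and does not touch the position that now varies. Compound 3 `COc1ccc2c(c1)[n+]([O-])c(NCCN(C)C)n[n+]2[O-]` differs from compound 2 as follows: methoxy in place of methyl on an aromatic carbon. For the measured compounds named here, no measured step bears on this change, so no shift beyond the scatter is expected; the step from compound 2 to compound 3 is estimated as a step that the limit leaves unreadable from compound 2 to compound 3. Compound 3 is thus expected to give about 60000000 nM, within 20000000 nM to 180000000 nM, most likely again reported as a limit.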

Compound 3, solubility: 46000000 nM
The estimate for compound 3 lay 1.3-fold (0.12 log units) above the measured number; the measured number falls inside the stated range.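

In this assay the change from methyl to methoxy on the aromatic carbon gives an at least 1.1-fold lower number from compound 2 to compound 3 (0.04 log units; that floor lies within the scatter) and nothing firmer, as the value of compound 2 is a limit and not a number: the limit of > 51000000 nM in this assay, at which 1 of the 3 values shown sits. Compound 3 gives 46000000 nM as a number and not a limit, so a compound carrying 2-(dimethylamino)ethyl now has a firm value on the shared core. The compounds shown leave open how far compound 2 truly lies from compound 3. They also leave open what an amine or a carboxylic acid on this aromatic carbon would do to the read-out.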